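Three Paw-Edema Results and One Untested Compound

The source may hold more compounds than are shown below. What is called first, only, known or untested is meant among the compounds shown, and "the series" means these compounds.

Compound 1 `c1ccc(-c2ccc(OCc3nnc(-c4ccccc4)o3)cc2)cc1` gives 18.2%.
Compound 2 `Clc1ccc(COc2nnc(COc3ccc(-c4ccccc4)cc3)o2)c(Cl)c1` gives 29.5%.
Compound 3 `CCCCn1c(S)nnc1COc1ccc(-c2ccccc2)cc1` gives 81.8%.

In a functional assay on the whole organism (strain Wistar) for inhibition, with Rattus norvegicus as the target, read by paw edema, with a stated time of 4 h, at a dose of 10 mg/kg by the oral route (a higher number here means more inhibition at the dose given (going by the name of the read-out), a lower number less inhibition), compound 3 stands highest of the three numbers; compound 2 is the nearest, a gap beyond the usual scatter, and compound 1 lies furthest away, also beyond the scatter. Compound 4 `Sc1nnc(COc2ccc(-c3ccccc3)cc2)n1-c1ccc(Br)cc1` differs from compound 3 in one place: 4-bromophenyl in place of butyl on an aromatic nitrogen. Among the compounds with values here, no measured pair in this set shows a change of that kind, so nothing here tells how this assay answers it. The step is expected to be a modest fall, a number 11.8 percentage points lower from compound 3 to compound 4 (beyond the scatter), small enough that it may sit within the scatter. Compound 4 is expected to give 70%, in a range from 45% to 90%.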

Compound 4, a percentage reported as inhibition, in the whole organism at one dose (the size of the read-out at that dose, not a potency): 31.8%
Beside the measured number, compound 4's estimate is 38.2 percentage points above it; the measured number lies below the stated range.
By their numbers in this assay, from the lowest: compound 1; then compounds 2 and 4 (each within the scatter of the next); then compound 3.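

In this assay, within the data shown here, the group on the aromatic nitrogen proves to matter: 4-bromophenyl in place of butyl gives a number 50 percentage points lower from compound 3 to compound 4 (beyond the scatter) and is a large step at a position that the earlier compounds did not vary. The high value of compound 3 therefore does not survive this change to its butyl group. Nothing given here accounts for the fall.

Going by these compounds, whether the loss follows from the phenyl ring itself or from its bromine stays open, since an unsubstituted phenyl does not appear here. So does the response to a shorter chain such as ethyl or a longer one such as hexyl on that nitrogen.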